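The source may report more compounds than this note shows. Statements on the series, on what has been measured and on what is new or still open speak of the compounds shown alone.

In a functional assay on PC-3 cells (Homo sapiens), read by MTT assay, with a stated time of 48 h (a higher number here means a weaker inhibitor, a lower number a stronger inhibitor), compound 1 `CCn1c(C(=O)NCCN(C)C)ccc1C(CC)(CC)c1ccc(OCC(O)C(C)(C)C)c(C)c1` gives 1630 nM, while compound 2 `CCn1c(C(=O)NCC(OC)OC)ccc1C(CC)(CC)c1ccc(OCC(O)C(C)(C)C)c(C)c1` gives 14600 nM, the higher of the two numbers. Compound 3 `CCn1c(C(=O)N(C)CCC#N)ccc1C(CC)(CC)c1ccc(OCC(O)C(C)(C)C)c(C)c1` keeps the shared core but changes the group on the carbonyl carbon: (2-cyanoethyl)(methyl)amino in place of (2,2-dimethoxyethyl)amino on a carbonyl carbon. Among the measured compounds shown here, only one measured step bears on this, a 9.0-fold higher number from compound 1 to compound 2 (0.95 log units; beyond the scatter), showing that this side chain can shift the number beyond the scatter. That step involves no nitrile, and neither group in the new change carries a net charge, so little movement is expected. The expected step is a 1.3-fold lower number from compound 2 to compound 3 (0.12 log units; within the scatter), which would stay within the scatter. For compound 3 the estimated value is 11000 nM, with an expected range of 4000 nM to 30000 nM.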

Compound 3, half-maximal inhibitory concentration: 1700 nM
The estimate for compound 3 lay 6.5-fold (0.81 log units) above the measured number; the whole stated range lies above it.
By their numbers in this assay, from the lowest: compounds 1 and 3 (each within the scatter of the next); then compound 2.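

In this assay, replacing (2,2-dimethoxyethyl)amino with (2-cyanoethyl)(methyl)amino on the carbonyl carbon moves the number beyond the scatter (an 8.6-fold lower number from compound 2 to compound 3 (0.93 log units; beyond the scatter)), while compound 3 stays within the scatter of compound 1 (a 1.0-fold higher number from compound 1 to compound 3 (0.02 log units; within the scatter)). Among the compounds shown here, the (2-(dimethylamino)ethyl)amino group of compound 1 is therefore not the only group here that reaches this level, and (2-cyanoethyl)(methyl)amino does so with 0 hydrogen-bond donors and no net charge. No evidence accounts for these steps. From the compounds shown here alone, it remains open whether the nitrile or the methyl on the amide nitrogen carries the step, and whether a carboxylic acid or a longer chain would behave alike.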